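From 3,4-dichlorophenyl to 3,5-dichlorophenyl: an expected cytotoxicity

The source may hold more compounds than are shown below. What is called first, only, known or untested is meant among the compounds shown, and "the series" means these compounds.

- compound 1 `COc1ccc(/C=C2\CCC/C(=C\c3ccc(O)cc3)C2=O)cc1OC` (17000 nM)
- compound 2 `COc1ccc(/C=C2\CCC/C(=C\c3ccc(Cl)c(Cl)c3)C2=O)cc1OC` (4400 nM)

In a functional assay on MCF7 cells (Homo sapiens) for cytotoxicity, read by MTT assay, with a stated time of 72 h (on this read-out lower numbers stand for stronger inhibition and higher numbers for weaker inhibition), compound 2 (4400 nM) holds the lower of the two numbers. Compound 3 `COc1ccc(/C=C2\CCC/C(=C\c3cc(Cl)cc(Cl)c3)C2=O)cc1OC` differs from it by one change, 3,5-dichlorophenyl in place of 3,4-dichlorophenyl on a double-bonded chain carbon bound to a double-bonded ring carbon. Among the compounds with values here, only one measured step bears on this, and only indirectly: a 3.9-fold lower number from compound 1 to compound 2 (0.59 log units; beyond the scatter), which brought in the 3,4-dichlorophenyl in place of 4-hydroxyphenyl. Within the data shown here, no measured pair compares two dichlorophenyl groups, so the data offer no direction for the new change. Compound 3 has the same atoms as compound 2, and its value is therefore expected to stay close to compound 2 (4400 nM) and not to return towards compound 1 (17000 nM). In this assay the expected change is a 1.0-fold higher number from compound 2 to compound 3 (0.01 log units; within the scatter) and thus none beyond the scatter. For compound 3 the estimated value is 4500 nM with 1800 nM to 11000 nM as the expected range.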

Compound 3, half-maximal inhibitory concentration: 3800 nM
Compound 3: middle estimate off by 1.2-fold (0.07 log units), on the high side; the range from low to high includes it.
By their numbers in this assay, from the lowest: compounds 3 and 2 (each within the scatter of the next); then compound 1.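

In this assay, 3,5-dichlorophenyl in place of 3,4-dichlorophenyl gives a 1.2-fold lower number from compound 2 to compound 3 (0.06 log units; within the scatter), so the two dichlorophenyl groups cannot be told apart at this place, on a double-bonded chain carbon bound to a double-bonded ring carbon. The step away from 4-hydroxyphenyl therefore does not depend on one particular arrangement of the two chlorines: 3,5-dichlorophenyl in place of that group gives a 4.5-fold lower number from compound 1 to compound 3 (0.65 log units; beyond the scatter), a step beyond the scatter like the earlier one to 3,4-dichlorophenyl. Nothing at hand explains why the two arrangements read alike.

The compounds shown leave open whether the chlorines themselves or simply the loss of the hydroxyl group accounts for the step from 4-hydroxyphenyl. A phenyl ring carrying a single chlorine, no substituent at all, or a trifluoromethyl group would be needed to separate the two.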